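Two Hydroxamic Acids Measured, a Third Awaits a Solubility Number

The compounds below may be only part of what the source reports. "The series", "measured", "known", "first", "only" and "open" are said of these compounds alone.

Measured so far:
- compound 1, `O=C(NC1(C(=O)NO)CCC1)c1ccc(C#Cc2ccccc2)cc1`: 5000 nM
- compound 2, `O=C(NC1(C(=O)NO)CCSCC1)c1ccc(C#Cc2ccccc2)cc1`: 1000 nM

For the measured compounds named here, in a physicochemical assay for solubility (a lower number here means a less soluble compound, a higher number a more soluble compound), compound 1 gives 5000 nM, the highest of the two numbers so far. Its nearest neighbour is compound 2, which in this assay gives 1000 nM, a gap that lies beyond the usual scatter. No single-point step between measured compounds is available, so nothing can be said about a cause for that gap.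

Compound 3, `CC(C)(NC(=O)c1ccc(C#Cc2ccccc2)cc1)C(=O)NO`, has not yet been measured in this assay. It differs from compound 1 in one place:

1-(hydroxycarbamoyl)-1-methylethyl in place of 1-(hydroxycarbamoyl)cyclobutyl on an amide-type nitrogen

The change is small in count: one ring of carbon only leaves, and a chain-free group enters on the same amide-type nitrogen. Going by the values given here, only two measured compounds exist and neither of them shares this exact change, so the expectation rests on compound 1 alone. The step of a 1.4-fold higher number from compound 1 to compound 3 (0.15 log units; within the scatter) is expected to be modest and upward, or none beyond the scatter. Compound 3 is therefore expected to give about 7000 nM, within 2500 nM to 20000 nM, because compound 1 already stands at 5000 nM.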

Compound 3, solubility: 182000 nM
Compound 3: the middle estimate sits 26-fold (1.41 log units) below what was measured; measured number outside the range, above it.
By their numbers in this assay, from the lowest: compound 2; then compound 1; then compound 3.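

In this assay, for the compounds shown here, the group on the amide-type nitrogen turns out to have a very large influence on the read-out: 1-(hydroxycarbamoyl)-1-methylethyl in place of 1-(hydroxycarbamoyl)cyclobutyl gives a 36-fold higher number from compound 1 to compound 3 (1.56 log units; beyond the scatter) in the only single-place comparison available so far. The change looks small on paper, since the hydrogen-bond donors and acceptors stay the same, neither group carries a net charge, and the clearest difference is that the four-membered ring of carbon only is gone. So a modest edit at this position can produce a step well beyond the scatter, yet nothing measured here bears on the reason for it.

The compounds shown leave open whether other groups at this position, such as a cyclopropyl ring, a cyclopentyl ring or two ethyl chains in place of the two methyl groups, would give numbers closer to compound 1 or closer to compound 3. They also leave open whether a step of this size would appear again if the same change were made on a core other than the one shared here.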